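The compounds below may be only part of what the source reports. "The series", "measured", "known", "first", "only" and "open" are said of these compounds alone.

Measured in an assay on Cerebral cortex for binding affinity to adenosine receptor A1 (Cavia porcellus), read by radioligand binding; on this read-out lower numbers stand for stronger inhibition and higher numbers for weaker inhibition:
Compound 1, `CCCn1c(=O)n(CCC(=O)O)c(=O)c2[nH]cnc21`: > 200000 nM, a limit of the assay.
Compound 2, `CCCn1c(=O)n(CCCN(C)C)c(=O)c2[nH]cnc21`: 43200 nM.
Compound 3, `CCCn1c(=O)n(C)c(=O)c2c1ncn2CCC(=O)O`: > 200000 nM, a limit of the assay.

Going by these compounds, compound 3 gives only a limit in this assay, namely (the limit of > 200000 nM in this assay, at which 2 of the 3 values shown sit), so its true number is unknown. Compound 4, `CCCn1c(=O)n(C)c(=O)c2c1ncn2CCC#N`, differs from it by cyano in place of carboxy on a saturated chain carbon, two bonds along the chain from an aromatic nitrogen. Within the data shown here, no measured pair shows exactly this change; the nearest is the step from compound 1 to compound 2, an at least 4.6-fold lower number from compound 1 to compound 2 (0.66 log units; beyond the scatter), which also removed the carboxy group and gave a lower number. From compound 3 to compound 4 the number is therefore expected to fall modestly, roughly an at least 2.0-fold lower number from compound 3 to compound 4 (0.30 log units; that floor lies within the scatter), though there remains a fair chance that the assay again reports only a limit. Compound 4 is estimated at 100000 nM, with a range from 30000 nM to 300000 nM.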

Compound 4, inhibition constant: 88600 nM
Compound 4: the middle estimate sits 1.1-fold (0.05 log units) above what was measured; the measured number falls inside the stated range.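

In this assay, the change from 2-carboxyethyl to 2-cyanoethyl gives an at least 2.2-fold lower number from compound 3 to compound 4 (0.35 log units; beyond the scatter). Losing the carboxy group thus lowered the number here too, on a chain at a different place on the shared core from the earlier step, and no carboxy compound shown gives more than a limit. The true size of this step stays unknown, since the value for compound 3 is only a limit of the assay: the limit of > 200000 nM in this assay, at which 2 of the 4 values shown sit.

Going by these compounds, whether an amine or an amide on this chain would lower the number further remains open. So does the effect of a longer chain carrying the nitrile.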